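The compounds below may be only part of what the source reports. "The series", "measured", "known", "first", "only" and "open" are said of these compounds alone.

Among the measured compounds shown here, compound 2 `Cc1nc(N)nc2c1cc(-c1cn[nH]c1)c(=O)n2[C@H]1CC[C@@H](OCO)CC1` gives 11.2 nM in an assay on BT-20 cells for inhibition of RAC-alpha serine/threonine-protein kinase (Homo sapiens) (a higher number here means a weaker inhibitor, a lower number a stronger inhibitor), the lowest of the three numbers so far. Compound 1 `COc1ccc(-c2cc3c(C)nc(N)nc3n([C@H]3CC[C@@H](OCO)CC3)c2=O)cn1` gives 21.6 nM, and a 1.9-fold lower number from compound 1 to compound 2 (0.29 log units; within the scatter). Compound 3 `Cc1nc(N)nc2c1cc(-c1cnc3ccccc3c1)c(=O)n2[C@H]1CC[C@@H](OCO)CC1` gives 104 nM; a 9.3-fold higher number from compound 2 to compound 3 (0.97 log units; beyond the scatter) and a 4.8-fold higher number from compound 1 to compound 3 (0.68 log units; beyond the scatter). Compound 4 `Cc1nc(N)nc2c1cc(-c1cn[nH]c1)c(=O)n2[C@H]1CC[C@H](OCO)CC1` differs from compound 2 in this way: the two compounds have the same atoms and bonds and differ only in configuration as drawn: 2 of 2 stereo elements differ (all stereocentres are inverted: mirror images); a stereocentre at a saturated ring carbon is drawn s in compound 2 and r in compound 4; a stereocentre at a saturated ring carbon is drawn s in compound 2 and r in compound 4. For the measured compounds named here, none of the measured steps bears on such a change; all three vary only the group on the aromatic carbon, with the saturated ring unchanged. With no guidance from the series, the expectation for compound 4 is a number near that of compound 2, a 1.3-fold higher number from compound 2 to compound 4 (0.10 log units; within the scatter), with a wide range. Compound 4 is estimated at 14 nM, between 5 nM and 50 nM.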

Compound 4, half-maximal inhibitory concentration: 25.9 nM
Estimate against measurement, compound 4: 1.9-fold (0.27 log units) below, within the range that was stated.
By their numbers in this assay, from the lowest: compounds 2, 1 and 4 (each within the scatter of the next, the first and the last beyond it); then compound 3.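

In this assay the inversion of both stereocentres on the saturated ring gives a 2.3-fold higher number from compound 2 to compound 4 (0.36 log units; beyond the scatter), the only step shown that touches this ring. Among the compounds shown here, the configuration of this ring therefore has a modest but readable effect on the number, whereas the earlier steps showed only changes on the aromatic carbon. The step can be assigned to configuration alone because of this: the fact that compounds 2 and 4 differ only in the configuration as drawn

Going by these compounds, whether the same inversion gives a similar step with 6-methoxypyridin-3-yl or quinolin-3-yl on the aromatic carbon remains open. Also open, on these data alone, is how an amine or a carboxylic acid on the saturated ring would compare in either configuration.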